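Swapping an acetamido for a hydroxy on a thiazole amide

The compounds below may be only part of what the source reports. "The series", "measured", "known", "first", "only" and "open" are said of these compounds alone.

Compound 1 `CC(=O)NCc1csc(NC(=O)c2cc(C(C)(C)C)nn2Cc2ccccc2)n1` is the more lipophilic of the two compounds measured in a physicochemical assay for lipophilicity, read by HPLC, at pH 7.4; a lower number here means a more polar compound, a higher number a more lipophilic compound: compound 1 gives 3.3, while compound 2 `NCc1csc(NC(=O)c2ccc(Cl)cc2)n1` gives 1.6, a gap beyond the scatter. Compound 3 `CC(C)(C)c1cc(C(=O)Nc2nc(CO)cs2)n(Cc2ccccc2)n1` has not yet been measured. It differs from compound 1 in one place: hydroxy in place of acetamido on a saturated chain carbon bound to an aromatic carbon. Within the data shown here, no comparable step between measured compounds is available, so the expectation rests on the change alone. The step from compound 1 to compound 3 is expected to be small, a number 0.10 log units higher from compound 1 to compound 3 (within the scatter), within the scatter. Compound 3 is therefore estimated at 3.4, in a range from 2.9 to 3.9.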

Compound 3, distribution coefficient: 3.4
For compound 3 middle estimate and measured number coincide at the digits printed; the range from low to high includes it.
By their numbers in this assay, from the lowest: compound 2; then compounds 1 and 3 (each within the scatter of the next).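

At this position, on a saturated chain carbon bound to an aromatic carbon, putting hydroxy in place of acetamido gives a number 0.10 log units higher from compound 1 to compound 3 (within the scatter) in this assay. A group of 4 heavy atoms thus gives way to one of 1 heavy atom, each with 1 hydrogen-bond donor and 1 hydrogen-bond acceptor, and the two compounds cannot be told apart in this measurement. Nothing available explains this result. On these data alone, how a carboxylic acid or a methoxy on this carbon would read remains open. So does the reading of a longer chain ending in hydroxy.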